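Sulfanyl replaces benzylamino at the diamine core

A few compounds are considered here, and "the series" means these few. Any claim that something is new, unique, unknown or untested is made for them only; others in the source may bear on it.

Three compounds of the series have numbers in a functional assay on MDA-MB-435 cells (Homo sapiens) for inhibition, read by sulforhodamine B assay, with a stated time of 48 h; a lower number here means that less compound is tolerated, a higher number that more compound is tolerated. Compound 1 `Nc1cc(N)c2nc(-c3ccccc3)c(NCc3ccc(Cl)c(Cl)c3)nc2c1` gives 52500 nM, compound 2 `Nc1cc(N)c2nc(-c3ccccc3)c(NCc3ccc(F)cc3)nc2c1` gives 6920 nM, and compound 3 `COc1ccc(CNc2nc3cc(N)cc(N)c3nc2-c2ccccc2)cc1` gives 46800 nM. Compound 2 thus stands lowest of the three, with the nearest neighbour being compound 3 at a 6.8-fold higher number from compound 2 to compound 3 (0.83 log units; beyond the scatter), and the change from compound 1 to compound 2 being a 7.6-fold lower number from compound 1 to compound 2 (0.88 log units; beyond the scatter); compound 1 and compound 3 sit within the scatter of each other, a 1.1-fold lower number from compound 1 to compound 3 (0.05 log units; within the scatter).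

Compound 4 `Nc1cc(N)c2nc(-c3ccccc3)c(Sc3ccc(Cl)c(Cl)c3)nc2c1` differs from compound 2 by (3,4-dichlorophenyl)sulfanyl in place of (4-fluorobenzyl)amino on an aromatic carbon, on an aromatic carbon next to the ring nitrogen and ortho to the phenyl group of the shared core. Two things change at once: the halogen pattern on the pendant ring and the group through which that ring is attached. Only the first has a precedent, the step from compound 1 to compound 2, a 7.6-fold lower number from compound 1 to compound 2 (0.88 log units; beyond the scatter), which runs the other way here and points to a higher number for compound 4. Going by the values given here, no measured step covers the exchange of the amino-bearing chain for the sulfanyl attachment, so that part adds width to the range rather than direction.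

Compound 4 is therefore expected to give about 35000 nM in this assay, estimated between 8000 nM and 120000 nM, a step from compound 2 of a 5.1-fold higher number from compound 2 to compound 4 (0.70 log units; beyond the scatter).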

Compound 4, concentration lethal to 50% of the cells: < 100000 nM
Compound 4: only a limit was reported (the forecaster's own chance of this, stated with the estimate: 15%); the middle value is on the limit's open side.
By their numbers in this assay, from the lowest: compound 2; then compounds 3 and 1 (each within the scatter of the next).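

In this assay compound 4 gives < 100000 nM, which is a limit and not a number. The step from compound 2 to compound 4 therefore cannot be read: the limit of < 100000 nM in this assay, at which 1 of the 4 values shown sits.

The compounds shown leave open where compound 4 actually lies, and how much the sulfanyl attachment alone changes the number, apart from the halogen pattern.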